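The compounds below may be only part of what the source reports. "The series", "measured", "known", "first", "only" and "open" are said of these compounds alone.

In an assay on CHO cells for displacement of a labelled ligand from 5-hydroxytryptamine receptor 7 (Homo sapiens) (on this read-out higher numbers stand for weaker inhibition and lower numbers for stronger inhibition), compound 1 `COc1ccc(S(=O)(=O)NCCCN2CCN(c3cccc(OC)c3)CC2)cc1` gives 339 nM. Compound 2 `COc1ccc(S(=O)(=O)NCCCN2CCN(c3ccc([N+](=O)[O-])cc3)CC2)cc1` reaches only the limit of the assay, > 10000 nM. The step from compound 1 to compound 2 was an at least 29-fold higher number from compound 1 to compound 2 (1.46 log units; beyond the scatter), which places compound 2 among the weakest values seen here. Compound 3 `COc1ccc(S(=O)(=O)NCCCN2CCN(C(=O)OCc3ccccc3)CC2)cc1` differs from compound 2 by benzyloxycarbonyl in place of 4-nitrophenyl on an amine nitrogen in a ring. Going by the values given here, the single measured step exchanges one aryl group for another on that ring nitrogen and does not cover a benzyloxycarbonyl group there, yet it shows that this position can shift the value far. Compound 3 is therefore expected to remain weak, an estimated 6000 nM with a range from 800 nM to 30000 nM, meaning an expected at least 1.6-fold lower number from compound 2 to compound 3 (0.22 log units; that floor lies within the scatter).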

Compound 3, half-maximal inhibitory concentration: > 10000 nM
Compound 3 ended at the assay's limit; the forecaster's own chance of this, stated with the estimate: 55%; middle value at least 1.6-fold (0.22 log units) away from the limit.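

Placing benzyloxycarbonyl on the ring nitrogen in place of 3-methoxyphenyl gives an at least 29-fold higher number from compound 1 to compound 3 (1.46 log units; beyond the scatter), so the large loss seen with 4-nitrophenyl also occurs with a group that is not an aryl group on that nitrogen. The step between compound 2 and compound 3 cannot be read, and the two groups cannot be ranked. Compound 3 also sits at a limit of the assay, not at a number: the limit of > 10000 nM in this assay, at which 2 of the 3 values shown sit.

Of the three groups shown, only 3-methoxyphenyl gives a value below that limit. As far as these compounds go, how a plain phenyl or a benzyl group on that nitrogen would read remains open.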